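Chloro to trifluoromethyl: expected step to compound 4

The source may hold more compounds than are shown below. What is called first, only, known or untested is meant among the compounds shown, and "the series" means these compounds.

In a functional assay on MCF7 cells (Homo sapiens) for inhibition, read by colorimetric assay and MTT assay, with a stated time of 72 h (on this read-out higher numbers stand for weaker inhibition and lower numbers for stronger inhibition), compound 1 `C=CCCCCOc1ncc(-c2ccccc2OC)n1C` gives 5000 nM. Compound 2 `C=CCCCCOc1ncc(-c2cc(C(C)C)ccc2OC)n1C` gives 18000 nM, and compound 3 `C=CCCCCOc1ncc(-c2cc(Cl)ccc2OC)n1C` gives 25000 nM. Compound 3 therefore stands at the upper end of the three numbers, a position it shares with compound 2 within the scatter. Against the unsubstituted parent, isopropyl in place of hydrogen gives a 3.6-fold higher number from compound 1 to compound 2 (0.56 log units; beyond the scatter), and chloro in place of hydrogen gives a 5.0-fold higher number from compound 1 to compound 3 (0.70 log units; beyond the scatter). Both steps are modest.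

The next step leads to compound 4 `C=CCCCCOc1ncc(-c2cc(C(F)(F)F)ccc2OC)n1C`, with trifluoromethyl in place of chloro on an aromatic carbon, para to a methoxy group: trifluoromethyl in place of chloro on an aromatic carbon. For the measured compounds named here, no measured step brings in trifluoromethyl, so the evidence is indirect. The closest guide is the exchange of one group for another at this same place, which gave only a 1.4-fold higher number from compound 2 to compound 3 (0.14 log units; within the scatter). The two steps from hydrogen show that the place itself can move the number, but they concern a different exchange. No step beyond the scatter is therefore expected in this assay, and neither direction is favoured. The expected change is a 1.0-fold lower number from compound 3 to compound 4 (0.02 log units; within the scatter). Compound 4 is estimated at 24000 nM, with an expected range of 11000 nM to 50000 nM.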

Compound 4, half-maximal inhibitory concentration: 61000 nM
Compound 4: middle estimate off by 2.5-fold (0.41 log units), on the low side, and the stated range ends below it.
By their numbers in this assay, from the lowest: compound 1; then compounds 2 and 3 (each within the scatter of the next); then compound 4.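

Unlike chloro and isopropyl, whose compounds stay within the scatter of each other, trifluoromethyl is clearly separated at this place in this assay: it gives a 2.4-fold higher number from compound 3 to compound 4 (0.39 log units; beyond the scatter) against chloro and a 3.4-fold higher number from compound 2 to compound 4 (0.53 log units; beyond the scatter) against isopropyl. The position therefore does not treat all substituents alike, and the step from hydrogen is no longer only modest, with a 12-fold higher number from compound 1 to compound 4 (1.09 log units; beyond the scatter) as a large loss of inhibition; all three substituents shown go the same way, so none improves on the unsubstituted parent. Nothing shown accounts for why trifluoromethyl stands apart from chloro and isopropyl.

With only hydrogen, isopropyl, chloro and trifluoromethyl shown at this place, it stays open whether an amine, a carboxylic acid or a hydroxyl group there would give a number lower than compound 1 gives at 5000 nM in this assay. From the compounds shown here alone, it also stays open whether the same order of substituents would hold with a longer chain on the oxygen of the shared core.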